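From Benzamide to Pyridine Carboxamide on a Shared Core

The compounds below may be only part of what the source reports. "The series", "measured", "known", "first", "only" and "open" are said of these compounds alone.

Of the compounds shown here, three built on one shared core have been tested in a functional assay on MCF7 cells (Homo sapiens) for antiproliferative activity, read by MTT assay, with a stated time of 48 h; on this read-out higher numbers stand for weaker inhibition and lower numbers for stronger inhibition. Compound 1 `CCCNc1cc2c(cn1)cc(NC(=O)c1cccc(-c3ccccc3)c1)c(=O)n2C` gives 6000 nM. Compound 2 `CN(C)CCNc1cc2c(cn1)cc(NC(=O)c1cc3ccccc3s1)c(=O)n2C` gives 12000 nM, and compound 3 `CN(C)CCNc1cc2c(cn1)cc(NC(=O)c1ccccc1)c(=O)n2C` gives 35100 nM, the highest of the three numbers, which on this read-out means the weakest inhibition. Among the compounds with values here, the only measured step that alters the ring on the carbonyl carbon is a 2.9-fold higher number from compound 2 to compound 3 (0.47 log units; beyond the scatter), and it is the sole clue to what an exchange at that place can do.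

Compound 4 `CN(C)CCNc1cc2c(cn1)cc(NC(=O)c1ccncc1)c(=O)n2C` differs from compound 3 in one place: pyridin-4-yl in place of phenyl on a carbonyl carbon. Within the data shown here, no measured pair exchanges a carbon-only ring for one carrying a nitrogen, so the step from compound 2 to compound 3 shows only that a swap of the ring at this position has moved the number modestly. For compound 4 the step of a 1.0-fold lower number from compound 3 to compound 4 (0.00 log units; within the scatter) is therefore expected to stay within the scatter, with a wide range to reflect the missing comparison. The estimate for compound 4 in this assay is 35000 nM, between 12000 nM and 100000 nM.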

Compound 4, half-maximal inhibitory concentration: 36600 nM
Beside the measured number, compound 4's estimate is 1.0-fold (0.02 log units) below it, within the range that was stated.
By their numbers in this assay, from the lowest: compounds 1 and 2 (each within the scatter of the next); then compounds 3 and 4 (each within the scatter of the next).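

In this assay, putting pyridin-4-yl in place of phenyl on the carbonyl carbon swaps a carbon-only ring for one carrying a nitrogen and a hydrogen-bond acceptor, yet the step is only a 1.0-fold higher number from compound 3 to compound 4 (0.02 log units; within the scatter), so in this pair the added ring nitrogen makes no readable difference. The step of a 3.1-fold higher number from compound 2 to compound 4 (0.48 log units; beyond the scatter) shows that compound 4, like compound 3, gives a number clearly apart from that of the 1-benzothiophen-2-yl amide, so the ring exchanges at this position differ in what they do. Nothing available explains why the ring nitrogen leaves the reading unchanged.

Still open, on these data alone, is whether pyridin-3-yl or pyridin-2-yl, with the ring nitrogen placed differently, would read the same. As far as these compounds go, it is also open what an amine or a carboxylic acid carried on this ring would do.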